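Replacing the propylphenyl arm of compound 1 with a dichlorophenyl

The source may hold more compounds than are shown below. What is called first, only, known or untested is meant among the compounds shown, and "the series" means these compounds.

Measured compounds:
Compound 1, `CCCc1ccc(/C=C/C(=O)Nc2ccc3nc(CCC)cc(N)c3c2)cc1`: 4 nM
Compound 2, `Cc1cc(N)c2cc(NC(=O)/C=C/c3ccc(C(F)(F)F)cc3)ccc2n1`: 8 nM
Compound 3, `CC(C)c1cc(N)c2cc(NC(=O)/C=C/c3ccc(C(F)(F)F)cc3)ccc2n1`: 2.1 nM

Compound 1 gives 4 nM in an assay on isolated protein for displacement of a labelled ligand from melanin-concentrating hormone receptor 1 (Homo sapiens) (a lower number here means a stronger inhibitor, a higher number a weaker inhibitor), and stands second highest of the three numbers. Its nearest neighbour is compound 3, and the gap between them is within the scatter; its furthest is compound 2, and that gap is within the scatter as well. Among the compounds with values here, the one step available in the set, a 3.8-fold lower number from compound 2 to compound 3 (0.58 log units; beyond the scatter), concerns the alkyl on the shared core and not the arm that changes here.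

Compound 4, `CCCc1cc(N)c2cc(NC(=O)/C=C/c3ccc(Cl)cc3Cl)ccc2n1`, has not been measured. It differs from compound 1 by 2,4-dichlorophenyl in place of 4-propylphenyl on a double-bonded chain carbon bound to a double-bonded chain carbon. Within the data shown here, no measured step touches this arm. What the data do show is that compound 1, with its propylphenyl, and compounds 2 and 3, each carrying a trifluoromethylphenyl, all sit within the scatter of one another, so the arm on the double-bonded chain carbon has tolerated one exchange without a shift beyond the scatter. A second chlorine is new to the set, and its effect cannot be read from anything measured.

Compound 4 is therefore expected to give 5 nM, within 1.5 nM to 16 nM, the estimated step of a 1.3-fold higher number from compound 1 to compound 4 (0.10 log units; within the scatter) being none beyond the scatter.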

Compound 4, half-maximal inhibitory concentration: 6.6 nM
The estimate for compound 4 lay 1.3-fold (0.12 log units) below the measured number, and the stated range covers the measured number.
By their numbers in this assay, from the lowest: compounds 3, 1, 4 and 2 (each within the scatter of the next, the first and the last beyond it).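

In this assay, the arm on the double-bonded chain carbon bound to a double-bonded chain carbon now has its first measured single-place exchange, a 1.7-fold higher number from compound 1 to compound 4 (0.22 log units; within the scatter), and this step stays within the scatter. On the shared core, with the propyl chain kept on the ring that carries the amine, the assay therefore does not distinguish 4-propylphenyl from 2,4-dichlorophenyl, even though one arm carries an alkyl chain and the other two chlorines. No accompanying measurement bears on why these two arms give numbers within the scatter of each other.

The compounds shown do not separate the contributions of the two chlorines, so it remains open how a phenyl with a single chlorine would compare with compound 4 or with compound 1. Nor do they show whether the arm would tolerate an amine or a carboxylic acid on its phenyl ring, or whether a longer chain in place of the propyl of 4-propylphenyl would stay within the scatter of compound 1.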